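Moving the carboxylic acid on the terminal ring

A few compounds are considered here, and "the series" means these few. Any claim that something is new, unique, unknown or untested is made for them only; others in the source may bear on it.

Compound 2 `O=C(O)c1cc(-c2cccc(COc3ccc4c(c3)CN(C3CCCC3)C4=O)c2)ccc1O` gives 20 nM
Compound 3 `O=C(O)c1cc(-c2cccc(COc3ccc4c(=O)n(C5CCCC5)sc4c3)c2)ccc1F` gives 240 nM
Compound 1 `CN(C)C(=O)c1cc(-c2cccc(COc3ccc4c(=O)n(C5CCCC5)sc4c3)c2)ccc1Cl` gives 980 nM

In an assay on HEK293 cells for positive allosteric modulation of metabotropic glutamate receptor 2 (Rattus norvegicus), read by thallium flux (a higher number here means that more compound is needed for the effect, a lower number that less compound is needed), compound 2 stands at the lowest of the three numbers; compound 3 lies beyond the scatter above it, and compound 1 lies furthest away. Compound 4 `O=C(O)c1ccc(-c2cccc(COc3ccc4c(c3)CN(C3CCCC3)C4=O)c2)c(Cl)c1` has not yet been measured. It differs from compound 2 by 4-carboxy-2-chlorophenyl in place of 3-carboxy-4-hydroxyphenyl on an aromatic carbon; the place is described as meta to a large group. Among the compounds with values here, no two measured compounds differ in only one place, and compounds 1 and 3 do not share the core of compound 2, so no single-step comparison exists. The step from compound 2 to compound 4 is expected to be a 5.0-fold higher number from compound 2 to compound 4 (0.70 log units; beyond the scatter), a loss beyond the scatter. Compound 4 is expected to give about 100 nM, between 25 nM and 400 nM.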

Compound 4, half-maximal effective concentration: 110 nM
Estimate against measurement, compound 4: 1.1-fold (0.04 log units) below; the measured number falls inside the stated range.
By their numbers in this assay, from the lowest: compound 2; then compound 4; then compound 3; then compound 1.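

In this assay, within the data shown here, 4-carboxy-2-chlorophenyl in place of 3-carboxy-4-hydroxyphenyl gives a 5.5-fold higher number from compound 2 to compound 4 (0.74 log units; beyond the scatter) on the shared core, the first comparison in which only this one place differs. A modest loss beyond the scatter is thus what this change costs, with a carboxylic acid present on the ring in both compounds. Nothing measured here bears on the reason for this step. The compounds shown leave open how much of the step belongs to the moved carboxylic acid and how much to chlorine replacing the hydroxyl. They also leave open how a tetrazole or a primary amide would fare at this place.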